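Swapping selenium for sulfur on a methyl-capped ring carbon

The source may report more compounds than this note shows. Statements on the series, on what has been measured and on what is new or still open speak of the compounds shown alone.

The measure used throughout is a functional assay on MCF7 cells (Homo sapiens) for cytotoxicity, read by MTT assay, with a stated time of 48 h; a higher number here means that more compound is tolerated, a lower number that less compound is tolerated. Compound 1, whose structure is `C=CCN1C(=O)CNC1=[Se]`, gives 44100 nM in this assay. Compound 2, with the structure `C=CCN1C(=O)/C(=C/c2ccccn2)N=C1[Se]C`, gives 7180 nM in this assay, the lowest of the two numbers shown; compound 1 sits at a clearly higher number, so compound 2 is the one whose cells tolerate less compound. Compound 3, with the structure `C=CCN1C(=O)/C(=C/c2ccccn2)N=C1SC`, has not yet been measured. It differs from compound 2 by a group of 2 heavy atoms (1 carbon, 1 sulfur; no ring) in place of a group of 2 heavy atoms (1 carbon, 1 selenium; no ring), on a carbon with a double bond to nitrogen. For the measured compounds named here, no measured pair in this set shows what such a swap does, so only a small step is expected, most likely toward a slightly higher number or none beyond the scatter. The step from compound 2 to compound 3 in this assay is expected to be a 1.4-fold higher number from compound 2 to compound 3 (0.14 log units; within the scatter). Compound 3 is therefore estimated at 10000 nM, within a range from 4000 nM to 25000 nM.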

Compound 3, half-maximal cytotoxic concentration: "not active" (no number reported)
For compound 3 the study gives words and no number, so the estimate cannot be set against anything.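

For the compounds shown here, compound 3 is reported only in words, as not active, so no step from compound 2 to compound 3 can be read. The compounds shown leave open how far replacing the selenium group with methylsulfanyl shifts the number, and no supporting data bear on this result.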